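This account rests on a few compounds, and the source may have more. Where it says the series, first, only, none or still open, it means among the compounds named here.

Measured so far in a functional assay on HEK293 cells for agonist activity at growth hormone secretagogue receptor type 1 (Homo sapiens), read by HTRF and inositol phosphate accumulation, with a stated time of 90 min, in the presence of a further agent that is not named here; a lower number here means a smaller maximal response, a higher number a larger maximal response:

Compound 1 `Cc1ccc2[nH]c(C(=O)N[C@H]3CCN(S(=O)(=O)N4CCCCC4)C[C@@H]3C(=O)NCCN(C)C)cc2c1` gives 105%.
Compound 2 `Cc1ccc2[nH]c(C(=O)N[C@H]3CCN(C(=O)c4cccnc4)C[C@@H]3C(=O)NCCN(C)C)cc2c1` gives 91%.
Compound 3 `Cc1ccc2[nH]c(C(=O)N[C@H]3CN(S(=O)(=O)c4ccccc4)C[C@@H]3C(=O)NC[C@@H]3CCCN3C)cc2c1` gives 87%.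

Compound 3 stands lowest of the three numbers: its gap to compound 2 lies within the scatter, its gap to compound 1 beyond it. Compound 4 `Cc1ccc2[nH]c(C(=O)N[C@H]3CN(S(=O)(=O)c4ccccc4)C[C@@H]3C(=O)N[C@H]3CCCNC3)cc2c1` differs from compound 3 in one place: piperidin-3-yl in place of (1-methylpyrrolidin-2-yl)methyl on an amide-type nitrogen.

Going by the values given here, the only measured step, a number 14 percentage points lower from compound 1 to compound 2 (beyond the scatter), concerns the amine nitrogen in the ring, not the amide-type nitrogen changed here, so it does not bear directly on this step. Among the compounds with values here, no measured pair varies the group on the amide-type nitrogen. With nothing pointing either way, a step within the scatter is expected, a number 2 percentage points lower from compound 3 to compound 4 (within the scatter).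

Compound 4 is therefore estimated at 85% in this assay, with a range from 68% to 102%.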

Compound 4, largest response reached (Emax), in percent of the reference or control that the assay uses: 98%
Estimate against measurement, compound 4: 13 percentage points below; measured number inside the range.
By their numbers in this assay, from the lowest: compounds 3, 2, 4 and 1 (each within the scatter of the next, the first and the last beyond it).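

In this assay, the group on the amide-type nitrogen can shift the maximal response: piperidin-3-yl in place of (1-methylpyrrolidin-2-yl)methyl gives a number 11 percentage points higher from compound 3 to compound 4 (beyond the scatter). The change alters ring size and the hydrogen-bond donor count together, so the step cannot be assigned to either alone. No measurement at hand accounts for the step.

A 1-methylpiperidin-3-yl group or a pyrrolidin-3-yl group on this nitrogen would begin to separate these features. Going by these compounds, whether the step carries over to the compounds with the 2-(dimethylamino)ethyl chain remains open.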